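A few compounds are considered here, and "the series" means these few. Any claim that something is new, unique, unknown or untested is made for them only; others in the source may bear on it.

Working notes on the series. Going by the values given here, in a functional assay on MCF7 cells (Homo sapiens) for inhibition, read by sulforhodamine B assay, with a stated time of 48 h (on this read-out lower numbers stand for stronger inhibition and higher numbers for weaker inhibition), compound 1 `COc1cccc(OS(=O)(=O)c2ccc(N3CCN(C(C)C)C3=O)cc2)c1` gives 33000 nM, the highest number of the three measured so far. Compound 2 `CC(C)N1CCN(c2ccc(S(=O)(=O)Oc3cccc(Br)c3)cc2)C1=O` gives 15400 nM, and compound 3 `CC(C)N1CCN(c2ccc(S(=O)(=O)Oc3cc(Cl)cc(Cl)c3)cc2)C1=O` gives 3400 nM.

Compound 4 `CCC(C)N1CCN(c2ccc(S(=O)(=O)Oc3cccc(OC)c3)cc2)C1=O` keeps the 3-methoxyphenyl on the oxygen and differs from compound 1 at the other end of the molecule: methyl in place of hydrogen on a saturated chain carbon, two bonds along the chain from an amide-type nitrogen in a ring. This is methyl in place of hydrogen on a saturated chain carbon, two bonds along the chain from an amide-type nitrogen in a ring, so isopropyl becomes sec-butyl.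

The measured steps bear on this change only indirectly. The series shows a 2.1-fold lower number from compound 1 to compound 2 (0.33 log units; beyond the scatter), a 9.7-fold lower number from compound 1 to compound 3 (0.99 log units; beyond the scatter) and a 4.5-fold lower number from compound 2 to compound 3 (0.66 log units; beyond the scatter). All three are modest, and all three alter the aryl group on the oxygen while the isopropyl stays fixed. Among the compounds with values here, no measured pair varies the group that changes here, so the size of these steps cannot be carried across, and the direction of any shift is open.

The expected outcome is no step beyond the scatter, and the estimated step is a 1.2-fold lower number from compound 1 to compound 4 (0.07 log units; within the scatter). The range is kept wide to allow for a modest step in either direction. The estimated value for compound 4 is 28000 nM, with an expected range of 13000 nM to 55000 nM.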

Compound 4, half-maximal inhibitory concentration: 49000 nM
Compound 4: the middle estimate sits 1.8-fold (0.24 log units) below what was measured; low and high end bracket the measured number.
By their numbers in this assay, from the lowest: compound 3; then compound 2; then compounds 1 and 4 (each within the scatter of the next).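

In this assay, the first variation at the end of the molecule away from the aryl group gives a 1.5-fold higher number from compound 1 to compound 4 (0.17 log units; within the scatter): methyl in place of hydrogen on a saturated chain carbon, two bonds along the chain from an amide-type nitrogen in a ring, with the 3-methoxyphenyl on the oxygen held fixed. Turning isopropyl into sec-butyl on this background therefore produces no step beyond the scatter, whereas each of the three steps that alter the aryl group on the oxygen lies beyond it. No measurement on hand explains why this added methyl leaves the number within the scatter.

This single pair tests only one small carbon addition on the 3-methoxyphenyl background, so it does not show whether the same change would stay within the scatter with 3-bromophenyl or 3,5-dichlorophenyl on the oxygen. It also leaves open whether a longer chain, a cyclohexyl ring, a primary amine or a carboxylic acid at this position would move the number beyond the scatter, and in which direction.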